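The compounds below may be only part of what the source reports. "The series", "measured", "known", "first", "only" and "open" are said of these compounds alone.

Compound 3 `O=C(Nc1cccc(Cc2ccccc2)c1)C1CCCN(C(=O)c2cc(C(F)(F)F)cc(C(F)(F)F)c2)C1` carries the shared core of this small series. In an ADME assay on PC-3 cells (Homo sapiens) for cytotoxicity, read by WST assay, tested at 100 uM (a lower number here means less inhibition, a higher number more inhibition at the concentration tested (going by the name of the read-out)), compound 3 gives 0%, level with compound 1 `CCc1cccc(NC(=O)C2CCCN(C(=O)c3cc(C(F)(F)F)cc(C(F)(F)F)c3)C2)c1`, which gives 0%, while compound 2 `O=C(Nc1cccc(Oc2ccccc2)c1)C1CCCN(C(=O)c2cc(C(F)(F)F)cc(C(F)(F)F)c2)C1` gives 1%; all three numbers sit together at the low end of what was measured. Compound 4 `C=CCOc1cccc(NC(=O)C2CCCN(C(=O)c3cc(C(F)(F)F)cc(C(F)(F)F)c3)C2)c1` differs from compound 3 by allyloxy in place of benzyl on an aromatic carbon. The measured steps that bear on this exchange are a number 1 percentage points higher from compound 1 to compound 2 (within the scatter), a number 1 percentage points lower from compound 2 to compound 3 (within the scatter) and no change at the digits printed from compound 1 to compound 3 (within the scatter), none of which leaves the scatter. Exchanging ethyl, phenoxy and benzyl at this aromatic carbon has not moved the read-out, so compound 4 is expected to follow suit with a number 1 percentage points higher from compound 3 to compound 4 (within the scatter). The estimate for compound 4 is 1%, between 0% and 10%.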

Compound 4, a percentage reported as inhibition, at one concentration (the size of the read-out at that concentration, not a potency): 0%
Compound 4: middle estimate off by 1 percentage points, on the high side; the measured number falls inside the stated range.
By their numbers in this assay, from the lowest: compounds 1, 3, 4 and 2 (each within the scatter of the next).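

At this aromatic carbon the series now includes allyloxy, which has no ring and has a double bond outside aromatic rings, and in this assay its exchange for benzyl gives no change at the digits printed from compound 3 to compound 4 (within the scatter). Set against the other two groups, allyl in place of phenyl on the oxygen gives a number 1 percentage points lower from compound 2 to compound 4 (within the scatter), and allyloxy in place of ethyl gives no change at the digits printed from compound 1 to compound 4 (within the scatter). The read-out therefore stays within the scatter across ethyl, phenoxy, benzyl and allyloxy, with no compound among these four going against that. Nothing available explains this flat result. From the compounds shown here alone, whether an amine or a carboxylic acid at this aromatic carbon would move the number beyond the scatter remains open.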